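Aryl amide variation in the quinazoline thiosemicarbazide series

The compounds below may be only part of what the source reports. "The series", "measured", "known", "first", "only" and "open" are said of these compounds alone.

Measured compounds:
compound 1 `Cc1ccc(C(=O)NC(=S)NNc2ncnc3ccccc23)cc1` — 11200 nM
compound 2 `COc1cc2ncnc(NNC(=S)NC(=O)c3ccc(Cl)cc3)c2cc1OC` — 9620 nM
compound 3 `COc1cc2ncnc(NNC(=S)NC(=O)c3ccccc3OC)c2cc1OC` — 16000 nM

In a functional assay on GLC82 cells (Homo sapiens) for cytotoxicity, read by MTT assay, with a stated time of 72 h (on this read-out higher numbers stand for weaker inhibition and lower numbers for stronger inhibition), compound 1 gives 11200 nM, which is the second highest of the three numbers. Its nearest neighbour is compound 2, and the gap between these two is within the scatter; the gap to compound 3 is also within the scatter, so no order among the three can be read from these numbers.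

Compound 4 `O=C(NC(=S)NNc1ncnc2ccccc12)c1ccccc1F` has not been measured. Against compound 1 it differs in one place: 2-fluorophenyl in place of 4-methylphenyl on a carbonyl carbon.

Within the data shown here, the only measured step that bears on it is the exchange of the aryl group on the carbonyl carbon between compound 2 and compound 3, which gave a 1.7-fold higher number from compound 2 to compound 3 (0.22 log units; within the scatter). With that step staying within the scatter, no movement beyond the scatter is expected for compound 4 in this assay; the expected step is a 1.1-fold higher number from compound 1 to compound 4 (0.03 log units; within the scatter).

Compound 4 is therefore estimated at 12000 nM, with a range from 6000 nM to 24000 nM.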

Compound 4, half-maximal inhibitory concentration: 6460 nM
For compound 4 the middle estimate is 1.9-fold (0.27 log units) above the measured one; low and high end bracket the measured number.
By their numbers in this assay, from the lowest: compounds 4, 2, 1 and 3 (each within the scatter of the next, the first and the last beyond it).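

In this assay, 2-fluorophenyl in place of 4-methylphenyl on a carbonyl carbon gives a 1.7-fold lower number from compound 1 to compound 4 (0.24 log units; within the scatter) and so stays within the scatter. Among these compounds, this is the first single exchange read on the core of compound 1, and it matches the exchange on the core of compound 2, where a 1.7-fold higher number from compound 2 to compound 3 (0.22 log units; within the scatter) also stays within the scatter; on both cores, these aryl exchanges at this place leave the number inside the scatter. No measurement at hand bears on what lies behind either step.

All the groups shown on this carbonyl carbon are substituted phenyl rings, so it remains open whether an amine, a carboxylic acid or a longer alkyl chain in their place would move the number beyond the scatter. Also open, on these data alone, is whether 2-fluorophenyl gives a comparable number on the core of compound 2.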